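The source may report more compounds than this note shows. Statements on the series, on what has been measured and on what is new or still open speak of the compounds shown alone.

Three measured compounds share one core and differ only in the length of the chain that joins the two ends of the molecule. Compound 1 `COc1ccccc1N1CCN(CCCCn2ncc(N3CCN(C(=O)c4ccco4)CC3)c(Cl)c2=O)CC1` carries the shortest chain; in an assay on cell membranes for binding affinity to Adrenergic receptor alpha-1 (Rattus norvegicus), read by radioligand binding (on this read-out higher numbers stand for weaker inhibition and lower numbers for stronger inhibition), compound 1 gives 33.5 nM. Compound 2 `COc1ccccc1N1CCN(CCCCCCn2ncc(N3CCN(C(=O)c4ccco4)CC3)c(Cl)c2=O)CC1` has a longer chain, and in this assay compound 2 gives 4.1 nM. Compound 3 `COc1ccccc1N1CCN(CCCCCCCn2ncc(N3CCN(C(=O)c4ccco4)CC3)c(Cl)c2=O)CC1` has the longest chain, and in this assay compound 3 gives 1.9 nM, the lowest number of the three; compound 2 stands nearest to it and compound 1 furthest, both gaps lying beyond the scatter.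

Compound 4 `O=C(c1ccco1)N1CCN(c2cnn(CCCCCCCN3CCN(c4ccccc4Cl)CC3)c(=O)c2Cl)CC1` keeps the chain of compound 3 and changes one group: chloro in place of methoxy on an aromatic carbon. Among the measured compounds shown here, no measured pair shows this change, so the size of its effect has to be guessed. The expectation is a modest rise in the number, from compound 3 to compound 4 a 2.4-fold higher number from compound 3 to compound 4 (0.37 log units; beyond the scatter), somewhat beyond the scatter but not large. Compound 4 is therefore estimated at 4.5 nM in this assay, with a range from 1.5 nM to 15 nM.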

Compound 4, inhibition constant: 11.5 nM
The estimate for compound 4 lay 2.6-fold (0.41 log units) below the measured number, and the stated range covers the measured number.
By their numbers in this assay, from the lowest: compound 3; then compound 2; then compound 4; then compound 1.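

Among the compounds shown here, the earlier compounds differ only in chain length, so compound 4 gives the first reading on the aromatic ring that carries the methoxy group. In this assay, with the chain held fixed, chloro in place of methoxy on an aromatic carbon, ortho to a large group, gives a 6.1-fold higher number from compound 3 to compound 4 (0.78 log units; beyond the scatter), so this position does respond to the choice of group, and of these two, methoxy gives the lower number. The data at hand offer no explanation for this rise.

This single pair cannot show whether the same change would have an effect of similar size on the shorter chains of compound 1 or compound 2. On these data alone, how fluoro, methyl or ethoxy would compare with methoxy and chloro at this position also remains open.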